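The source may report more compounds than this note shows. Statements on the series, on what has been measured and on what is new or still open speak of the compounds shown alone.

Of the compounds shown here, three of one family have been measured in a physicochemical assay for lipophilicity; a higher number here means a more lipophilic compound, a lower number a more polar compound. Compound 1 `CC(/C=C/CC(C)CCCC(C)C)=C\C(=O)OC(C)(C)C` gives 7.56, compound 2 `COC(C)(C)CCCC(C)C/C=C/C(C)=C/C(=O)OC(C)(C)C` gives 6.36, and compound 3 `CC(/C=C/CC(C)CCCC(C)C)=C\C(=O)SC(C)C` gives 8.39. Compound 2 has the lowest of the three numbers: the nearest is compound 1, from which it differs by a number 1.20 log units lower from compound 1 to compound 2 (beyond the scatter), and the furthest is compound 3.

The step of interest leads from compound 2 to compound 4 `COC(C)(C)CCCC(C)C/C=C/C(C)=C/C(=O)N(C)C`, which has not yet been measured. The change is dimethylamino in place of tert-butoxy on a carbonyl carbon. Of the two measured steps, only one touches the same place in the molecule: the step of a number 0.83 log units higher from compound 1 to compound 3 (beyond the scatter), in which isopropylsulfanyl replaced tert-butoxy on the carbonyl carbon and the value rose. Here the exchange runs the other way in kind, with the tert-butoxy group leaving and the smaller dimethylamino group entering, so that the count of heavy atoms falls and the one hydrogen-bond acceptor of the leaving group is not replaced. A drop well beyond the scatter is therefore expected, larger than the modest rise seen when the thioester was formed. The expected step is a number 2.06 log units lower from compound 2 to compound 4 (beyond the scatter). Compound 4 is estimated at 4.3, within a range from 3.5 to 5.1.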

Compound 4, partition coefficient: 3.74
Beside the measured number, compound 4's estimate is 0.56 log units above it, and the stated range covers the measured number.
By their numbers in this assay, from the lowest: compound 4; then compound 2; then compound 1; then compound 3.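

In this assay, the group on the carbonyl carbon can evidently move the number down as well as up: the new exchange gives a number 2.62 log units lower from compound 2 to compound 4 (beyond the scatter), while the earlier one at this place gave a number 0.83 log units higher from compound 1 to compound 3 (beyond the scatter) and so pointed the other way. Tert-butoxy leaves in both steps, so the direction follows the entering group, with dimethylamino and isopropylsulfanyl on opposite sides, although compound 2 also carries the methoxy group that compound 1 lacks. No measurement bears on why the change from tert-butoxycarbonyl to dimethylcarbamoyl lowers the number this far.

The compounds shown leave open whether dimethylamino would give a step of similar size on the chain without the methoxy group, since both measured exchanges at the carbonyl carbon stand on different chains. They also leave open how other groups at this place would compare, such as diethylamino, a plain amino group or the hydroxyl group of a carboxylic acid, and so whether the size of this drop is particular to dimethylamino.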